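Solubility notes: benzyloxy to (oxan-4-yl)oxy in the pyrazole series

A few compounds are considered here, and "the series" means these few. Any claim that something is new, unique, unknown or untested is made for them only; others in the source may bear on it.

Measured compounds:
compound 1 `Nc1nccc(-c2cc3c4c(n[nH]c4c2)Nc2ccncc2O3)n1`, 10000 nM
compound 2 `Nc1nccc(-c2cc(OCc3ccccc3)c3c(N)n[nH]c3c2)n1`, 85000 nM

In a physicochemical assay for solubility, read by LC-MS, in phosphate buffer, measured as kinetic solubility, with a stated time of 24 h, at 25 degrees C, at pH 7.4 (on this read-out higher numbers stand for higher solubility and lower numbers for lower solubility), compound 2 holds the higher of the two numbers, and compound 1 sits a step below it, beyond the scatter. Compound 3 `Nc1nccc(-c2cc(OC3CCOCC3)c3c(N)n[nH]c3c2)n1` is not yet measured. It differs from compound 2 in one place (oxan-4-yl in place of benzyl on an oxygen on an aromatic ring). Within the data shown here, no measured pair shows this change, so its size is unknown. The step of a 1.8-fold higher number from compound 2 to compound 3 (0.25 log units; within the scatter) is expected to be modest and upward, possibly within the scatter. Compound 3 is therefore estimated at 150000 nM, with a range from 60000 nM to 400000 nM.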

Compound 3, solubility: 770000 nM
Compound 3: middle estimate off by 5.1-fold (0.71 log units), on the low side; the whole stated range lies below it.
By their numbers in this assay, from the lowest: compound 1; then compound 2; then compound 3.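

Among these compounds, the pair of compound 2 and compound 3 is the first to differ in one place, so the earlier compounds gave no reading of this change at this position. With oxan-4-yl in place of benzyl on an oxygen on an aromatic ring, this assay gives a 9.1-fold higher number from compound 2 to compound 3 (0.96 log units; beyond the scatter), a single pair on a single core. Nothing measured here accounts for the size of this step.

Going by these compounds, it remains open whether the step follows the ring oxygen of oxan-4-yl or the departure of the benzyl ring. A cyclohexyl group or a piperidin-4-yl amine on the same oxygen would help separate the two.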